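The compounds below may be only part of what the source reports. "The series", "measured", "known", "first", "only" and "open" are said of these compounds alone.

Measured so far in an assay on isolated protein for inhibition of Amine oxidase [flavin-containing] A (Homo sapiens), read by fluorescence and Amplex Red, with a stated time of 15 min, tested at 50 uM; on this read-out lower numbers stand for less inhibition and higher numbers for more inhibition at the one concentration tested (going by the name of the read-out):
compound 1 `C#CCN(CCC)Cc1cn(-c2cc(NC(=S)NCC)ncn2)cn1` gives 1.76%
compound 2 `C#CCN(CCCC)Cc1cn(-c2cc(NC(=S)NCC)ncn2)cn1` gives 2.43%
compound 3 `C#CCN(CC#C)Cc1cn(-c2cc(NC(=S)NCC)ncn2)cn1` gives 15.5%

Compound 1 sits lowest of the three numbers, though its nearest neighbour is within the scatter: a number 0.7 percentage points higher from compound 1 to compound 2 (within the scatter). Among the measured compounds shown here, the only change that moves the read-out beyond the scatter is ethynyl in place of an alkyl chain on the amine carbon: a number 13.7 percentage points higher from compound 1 to compound 3 (beyond the scatter) and a number 13.1 percentage points higher from compound 2 to compound 3 (beyond the scatter), both modest.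

Compound 4 `C#CCNCCCc1cn(-c2cc(NC(=S)NCC)ncn2)cn1` is not yet measured. It differs from compound 1 thus: a group of 6 heavy atoms (5 carbon, 1 nitrogen; no ring) in place of a group of 7 heavy atoms (6 carbon, 1 nitrogen; no ring), on a saturated chain carbon bound to an aromatic carbon. The amine keeps its propargyl group; the change removes the propyl chain and the nitrogen becomes a secondary amine one carbon further from the shared core.

For the measured compounds named here, no measured step is the same change. The lengthening of the alkyl chain on the nitrogen, as in the step from compound 1 to compound 2, left the number within the scatter, which suggests that what the alkyl chain does at the amine matters little here. The larger rise seen with compound 3 rests on adding a second ethynyl, which compound 4 does not carry. An estimate close to compound 1 is therefore expected, with a step of a number 3.2 percentage points higher from compound 1 to compound 4 (within the scatter) that stays within the scatter. For compound 4 a value of 5% is expected, in the range 0% to 20%.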

Compound 4, a percentage reported as inhibition, at one concentration (the size of the read-out at that concentration, not a potency): 31.4%
Beside the measured number, compound 4's estimate is 26.4 percentage points below it, outside the stated range (above it).
By their numbers in this assay, from the lowest: compounds 1 and 2 (each within the scatter of the next); then compound 3; then compound 4.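

In this assay, changes on a saturated chain carbon bound to an aromatic carbon move the number much further than lengthening the alkyl chain on the amine did (a number 0.7 percentage points higher from compound 1 to compound 2 (within the scatter)): 2-(propargylamino)ethyl at this place gives a number 29.6 percentage points higher from compound 1 to compound 4 (beyond the scatter) and a number 29 percentage points higher from compound 2 to compound 4 (beyond the scatter). The same group also exceeds dipropargylamino, with a number 15.9 percentage points higher from compound 3 to compound 4 (beyond the scatter), so a second ethynyl is not required for the highest of the four numbers, and the entering group counts a hydrogen-bond donor that the group leaving compound 1 lacks. Nothing measured here gives a reason for these rises.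

Compound 4 combines loss of the propyl chain with a longer link between the amine and the shared core, and the compounds shown do not separate these two changes. A tertiary amine on the same longer link, a shorter secondary amine with a single carbon link, or a primary amine in place of the propargylamino group would help divide the rise, and all of these numbers remain readings at one concentration rather than potencies.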